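A few compounds are considered here, and "the series" means these few. Any claim that something is new, unique, unknown or untested is made for them only; others in the source may bear on it.

In an assay on CHO cells for positive allosteric modulation of metabotropic glutamate receptor 5 (Rattus norvegicus), read by FLIPR (on this read-out higher numbers stand for an effect only at larger amounts of compound and lower numbers for an effect already at smaller amounts), the three measured compounds gave these values:

Compound 1 `O=C(Nc1ccc(Cl)cc1CN1C(=O)c2ccccc2C1=O)c1ncccn1` gives < 1000 nM, which is a limit of the assay and not a number.
Compound 2 `O=C(Nc1ccc(Cl)cc1CN1C(=O)c2ccccc2C1=O)c1ccco1` gives < 1000 nM, also a limit of the assay.
Compound 3 `O=C(Nc1ccc(Cl)cc1CN1C(=O)c2ccccc2C1=O)c1cncs1` gives < 1000 nM, again a limit of the assay.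

Compound 3 thus stands only at a limit, and the two other values shown stand there too: the limit of < 1000 nM in this assay, at which 3 of the 3 values shown sit. The steps among the measured compounds, a step that the two limits leave unreadable from compound 1 to compound 2, a step that the two limits leave unreadable from compound 1 to compound 3 and a step that the two limits leave unreadable from compound 2 to compound 3, all run from one limit to another, so their size cannot be read.

Compound 4 `O=C(Nc1ccc(Cl)cc1CN1C(=O)c2ccccc2C1=O)c1ccccc1C(F)(F)F` differs from compound 3 in one place: 2-(trifluoromethyl)phenyl in place of 1,3-thiazol-5-yl on a carbonyl carbon. All three measured steps change the group on a carbonyl carbon, and so they are the ones that bear on this exchange, yet none of them has a readable size. The expectation for compound 4 can therefore rest only on the fact that every measured compound sits at the limit. For compound 4 the step that the limit leaves unreadable from compound 3 to compound 4 is expected, which means no clear move beyond the scatter in either direction. Compound 4 is estimated at 400 nM in this assay, with a range from 60 nM to 3000 nM.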

Compound 4, half-maximal effective concentration: < 1000 nM
Compound 4: no number, only a limit (the forecaster's own chance of this, stated with the estimate: 55%); the middle value does not contradict the limit.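

Compound 4 gives < 1000 nM, which is a limit of the assay and not a number. Its steps from compound 1, compound 2 and compound 3 therefore cannot be read, and all four compounds stand together: the limit of < 1000 nM in this assay, at which 4 of the 4 values shown sit. The compounds shown leave open how far their actual values in this assay lie apart, and whether the group on the carbonyl carbon matters there at all.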